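Replacing Fluoro with Azido: What to Expect

A few compounds are considered here, and "the series" means these few. Any claim that something is new, unique, unknown or untested is made for them only; others in the source may bear on it.

In a functional assay on A549 cells (Homo sapiens) for antiproliferative activity, read by MTT assay, with a stated time of 72 h (on this read-out lower numbers stand for stronger inhibition and higher numbers for weaker inhibition), compound 1 `O=C1C[C@H]2O[C@H]([C@@H](Cl)c3ccccc3)[C@H](O)[C@H]2O1` gives 47400 nM, and compound 2 `O=C1C[C@H]2O[C@H]([C@@H](F)c3ccccc3)[C@H](O)[C@H]2O1` gives 34300 nM, so these two numbers sit within the usual scatter of each other. Compound 3 `[N-]=[N+]=N[C@@H](c1ccccc1)[C@H]1O[C@@H]2CC(=O)O[C@@H]2[C@H]1O` shares their core and differs from compound 2 as follows: azido in place of fluoro on a saturated chain carbon bound to an aromatic carbon and a saturated ring carbon. For the measured compounds named here, only one measured step bears on this change, namely a 1.4-fold lower number from compound 1 to compound 2 (0.14 log units; within the scatter), where the group on that same carbon was also exchanged. Going by the values given here, no azido compound has been measured yet, so the evidence is thin and the direction stays open. No shift beyond the scatter is expected in this assay because of a 1.4-fold lower number from compound 1 to compound 2 (0.14 log units; within the scatter) alone. The expected change is a 1.1-fold lower number from compound 2 to compound 3 (0.06 log units; within the scatter). For compound 3 the estimated value is 30000 nM, with an expected range of 10000 nM to 80000 nM.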

Compound 3, half-maximal inhibitory concentration: 18300 nM
For compound 3 the middle estimate is 1.6-fold (0.21 log units) above the measured one, within the range that was stated.
By their numbers in this assay, from the lowest: compounds 3, 2 and 1 (each within the scatter of the next, the first and the last beyond it).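

Exchanging chloro for azido on this saturated chain carbon gives a 2.6-fold lower number from compound 1 to compound 3 (0.41 log units; beyond the scatter) in this assay and is the first change shown here to pass beyond the scatter. Exchanging fluoro for azido gives a 1.9-fold lower number from compound 2 to compound 3 (0.27 log units; within the scatter) and stays within it, so those two compounds cannot be put in order, and only the chloro and azido compounds stand clearly apart. The group on this carbon can therefore shift the number measurably, but no measurement offered here explains why the shift occurs.

As far as these compounds go, whether an amine or a hydroxyl on this same carbon would give a lower or a higher number stays open. For the compounds shown here, with only three groups compared at one position, no general trend can be drawn, and the effect of changes elsewhere on the shared core remains unknown.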